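Bromo for trifluoromethyl in a series at its limit

A few compounds are considered here, and "the series" means these few. Any claim that something is new, unique, unknown or untested is made for them only; others in the source may bear on it.

Measured in a functional assay on AGS cells (Homo sapiens) for inhibition, read by MTT assay, with a stated time of 72 h; on this read-out higher numbers stand for weaker inhibition and lower numbers for stronger inhibition:
- compound 1 `O=C(NCc1ccc(NC(=O)c2cc(-c3ccccc3)ccc2N2CCCC2)cc1)OCc1cccnc1`: > 100000 nM (a limit)
- compound 2 `O=C(NCc1ccc(NC(=O)c2cc(C(F)(F)F)ccc2N2CCCC2)cc1)OCc1cccnc1`: > 100000 nM (a limit)

Compound 2 stands at > 100000 nM, which is a limit of the assay and not a number. Among the compounds with values here, the same is true of the only other measured compound, so the whole picture so far is the limit of > 100000 nM in this assay, at which 2 of the 2 values shown sit. Within the data shown here, the one measured change is a step that the two limits leave unreadable from compound 1 to compound 2, with trifluoromethyl in place of phenyl on an aromatic carbon. Compound 3 `O=C(NCc1ccc(NC(=O)c2cc(Br)ccc2N2CCCC2)cc1)OCc1cccnc1` has not yet been measured. It differs from compound 2 by bromo in place of trifluoromethyl on an aromatic carbon, with bromo in place of trifluoromethyl on an aromatic carbon, para to a pyrrolidin-1-yl group. Among the measured compounds shown here, the single measured step offers no size to carry over, and it gives no direction either. No step beyond the scatter is therefore expected in this assay, and the assay may well report only a limit again. The expected change is a number no higher from compound 2 to compound 3 (the limit leaves the size open). For compound 3 the estimated value is 100000 nM, with an expected range from 30000 nM to 300000 nM.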

Compound 3, half-maximal inhibitory concentration: > 100000 nM
Compound 3 was reported as a limit; the forecaster's own chance of this, stated with the estimate: 75%; the middle value lies on the limit itself.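

Compound 3 gives > 100000 nM in this assay and this is a limit of the assay, not a number. The steps from compound 1 and from compound 2 to compound 3 therefore cannot be read, and all three compounds share one result: the limit of > 100000 nM in this assay, at which 3 of the 3 values shown sit. The compounds shown leave open how phenyl, trifluoromethyl and bromo rank against one another, and whether any group at this place on the shared core gives a measurable value.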